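Sulfonamide series: dimethylphenyl extension of compound 3

A few compounds are considered here, and "the series" means these few. Any claim that something is new, unique, unknown or untested is made for them only; others in the source may bear on it.

Three members of the series have been run in a functional assay on 143B cells (Homo sapiens) for antiproliferative activity, read by MTT assay, with a stated time of 48 h; a lower number here means a stronger inhibitor, a higher number a weaker inhibitor. Compound 1 `O=C(/C=C/c1cccc(NS(=O)(=O)c2cccc(Cl)c2)c1)c1nc2ccccc2[nH]1` gives 2510 nM. Compound 2 `Cc1cccc(S(=O)(=O)Nc2cccc(/C=C/C(=O)c3nc4ccccc4[nH]3)c2)c1` gives 791 nM, and compound 3 `Cc1ccc(S(=O)(=O)Nc2cccc(/C=C/C(=O)c3nc4ccccc4[nH]3)c2)cc1` gives 3220 nM. Compound 3 holds the highest of the three numbers, but one of its two gaps is small (a 1.3-fold higher number from compound 1 to compound 3 (0.11 log units; within the scatter)), whereas the other lies beyond the scatter (a 4.1-fold higher number from compound 2 to compound 3 (0.61 log units; beyond the scatter)).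

Compound 4 `Cc1ccc(S(=O)(=O)Nc2cccc(/C=C/C(=O)c3nc4ccccc4[nH]3)c2)cc1C` differs from compound 3 by methyl in place of hydrogen on an aromatic carbon. Going by the values given here, no measured pair carries this exact change. Among the compounds with values here, the steps that bear on it concern the same ring: a 3.2-fold lower number from compound 1 to compound 2 (0.50 log units; beyond the scatter) and a 4.1-fold higher number from compound 2 to compound 3 (0.61 log units; beyond the scatter). Both point the same way, the 3-methylphenyl of compound 2 going with a lower number than either the 3-chlorophenyl of compound 1 or the 4-methylphenyl of compound 3. Compound 4 keeps the 4-methylphenyl pattern of compound 3 and adds the methyl that compound 2 carries. A modest lowering is therefore expected, a 2.1-fold lower number from compound 3 to compound 4 (0.33 log units; beyond the scatter). Compound 4 is estimated at 1500 nM, range 600 nM to 4000 nM.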

Compound 4, half-maximal inhibitory concentration: 5050 nM
The estimate for compound 4 lay 3.4-fold (0.53 log units) below the measured number, and the stated range ends below it.
By their numbers in this assay, from the lowest: compound 2; then compounds 1, 3 and 4 (each within the scatter of the next).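

In this assay, the 3,4-dimethylphenyl group of compound 4 joins the methyl of the 3-methylphenyl in compound 2 to the methyl of the 4-methylphenyl in compound 3, and the low number of compound 2 does not carry over: a 6.4-fold higher number from compound 2 to compound 4 (0.81 log units; beyond the scatter). On the 4-methylphenyl ring, the new methyl, ortho to a methyl group, gives no change beyond the scatter, with a 1.6-fold higher number from compound 3 to compound 4 (0.20 log units; within the scatter), and the same holds against the 3-chlorophenyl group, with a 2.0-fold higher number from compound 1 to compound 4 (0.30 log units; within the scatter), so among these four compounds only compound 2 stands apart. No evidence on the cause of this result is available.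

Still open, on these data alone, is whether the low number of compound 2 is tied to methyl itself or would survive with an ethyl, a methoxy or an amine in its place. Also open, as far as these compounds go, is how a plain phenyl compares with these rings.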